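A few compounds are considered here, and "the series" means these few. Any claim that something is new, unique, unknown or untested is made for them only; others in the source may bear on it.

Compound 1 `CCCCCCCCNC(=O)[C@@H]1CSC(c2cc(OC)c(OC)c(OC)c2)N1` and compound 2 `CCCCCCCCCCNC(=O)[C@@H]1CSC(c2cc(OC)c(OC)c(OC)c2)N1` share one core, while compound 3 `CCCCCCCCCCCCNC(=O)[C@@H]1CSC(c2ccc(NC(C)=O)cc2)N1` and compound 4 `CCCCCCCCCCCCCCNC(=O)[C@@H]1CSC(c2ccc(NC(C)=O)cc2)N1` share another; the difference between the two cores is not broken down here. In a functional assay on cells (Homo sapiens) for antiproliferative activity, read by sulforhodamine B assay, with a stated time of 48 h (a higher number here means a weaker inhibitor, a lower number a stronger inhibitor), compound 1 gives 17100 nM and compound 2 gives 14500 nM; the change ethyl in place of hydrogen on a saturated chain carbon, eight bonds along the chain from an amide-type nitrogen gave a 1.2-fold lower number from compound 1 to compound 2 (0.07 log units; within the scatter). Compound 3 gives 2400 nM in this assay. Compound 4 differs from compound 3 by the same kind of change, (ethyl in place of hydrogen on a saturated chain carbon, ten or more bonds along the chain from an amide-type nitrogen), only at a different point of the chain. Since the earlier step stayed within the scatter, compound 4 is expected to show a step of about a 1.2-fold lower number from compound 3 to compound 4 (0.08 log units; within the scatter) in this assay, resting on the value of compound 3 2400 nM. Compound 4 is estimated at 2000 nM, between 900 nM and 5000 nM.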

Compound 4, half-maximal inhibitory concentration: 2300 nM
The estimate for compound 4 lay 1.2-fold (0.06 log units) below the measured number; the measured number falls inside the stated range.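

In this assay, ethyl in place of hydrogen on a saturated chain carbon, ten or more bonds along the chain from an amide-type nitrogen, gave a 1.0-fold lower number from compound 3 to compound 4 (0.02 log units; within the scatter). Set beside the earlier step, the change reads alike on the two cores: the same change on two cores in this assay, a 1.2-fold lower number (0.07 log units; within the scatter) from compound 1 to compound 2 and a 1.0-fold lower number (0.02 log units; within the scatter) from compound 3 to compound 4, 1.1-fold (0.05 log units) apart, within the scatter of two such steps. This shows that lengthening the chain by ethyl left no readable step at the two chain points shown, one on each core, but neither step lies beyond the scatter, so it does not show how a real effect of the change would carry from one core to another.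

Still open, on these data alone, is how a longer chain, or a chain ending in an amine or a carboxylic acid, would read on either core. Also open, as far as these compounds go, is what the core alone contributes, for every pair across the two cores also differs in chain length.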